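Methyl to Hydrogen on the Aryl Oxygen: Cytotoxicity Shift

The source may hold more compounds than are shown below. What is called first, only, known or untested is meant among the compounds shown, and "the series" means these compounds.

Measured compounds, with their values in an ADME assay on L6 cells (Rattus norvegicus) for cytotoxicity; a lower number here means a stronger inhibitor, a higher number a weaker inhibitor:
compound 1, `COc1cc(C(=N)NC(C)C)ccc1-c1cc2cc(C(=N)NC(C)C)ccc2o1`, gives 98100 nM;
compound 2, `COc1ccc(C2=NCCN2)cc1-c1cc2cc(C3=NCCN3)ccc2o1`, gives 30800 nM;
compound 3, `CC(C)NC(=N)c1ccc(-c2cc3cc(C(=N)NC(C)C)ccc3o2)c(O)c1`, is reported only as a limit, > 183000 nM.

Compounds 1 and 3 share a core and differ in one place: hydrogen in place of methyl on an oxygen on an aromatic ring. Across this pair the step is an at least 1.8-fold higher number from compound 1 to compound 3 (0.27 log units; that floor lies within the scatter). The floor of that step rests on (the limit of > 183000 nM in this assay, at which 1 of the 3 values shown sits), so the true size is not fixed by the data and may be larger. Among the two numbers that are not limits, compound 2 gives the lowest, and its nearest neighbour is compound 1, which gives a number that stands beyond the scatter above it. How the core of compound 2 differs from that of compound 1 is not broken down here.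

The unmeasured compound 4, `Oc1ccc(C2=NCCN2)cc1-c1cc2cc(C3=NCCN3)ccc2o1`, stands to compound 2 as compound 3 stands to compound 1: hydrogen in place of methyl on an oxygen on an aromatic ring. The place is the same in both pairs. This is the same change. The expectation for compound 4 therefore rests on compound 2 and its value 30800 nM, shifted by the earlier step of an at least 1.8-fold higher number from compound 1 to compound 3 (0.27 log units; that floor lies within the scatter). The step the estimate means is a 2.3-fold higher number from compound 2 to compound 4 (0.36 log units; beyond the scatter), and it is expected rather than known. Compound 4 is expected to give about 70000 nM in this assay, in a range from 30000 nM to 180000 nM.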

Compound 4, half-maximal inhibitory concentration: > 199000 nM
Compound 4 gave a limit, no number (the forecaster's own chance of this, stated with the estimate: 20%); middle value at least 2.8-fold (0.45 log units) from the limit.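

On the core of compound 2, the change from methoxy to hydroxy gives an at least 6.4-fold higher number from compound 2 to compound 4 (0.81 log units; beyond the scatter) in this assay, so on this core the rise stands clear of the scatter even at its floor. Compound 4 is reported only as a limit, > 199000 nM, so this step marks the smallest size the data allow and not a measured size. The result shows that the change can carry a real rise onto a second core, but the earlier pair establishes no rise of its own, and neither pair fixes a size, so it does not show that the change acts to the same extent on both cores: the same change on two cores in this assay, an at least 1.8-fold higher number (0.27 log units; that floor lies within the scatter) from compound 1 to compound 3 and an at least 6.4-fold higher number (0.81 log units; beyond the scatter) from compound 2 to compound 4; the limit leaves it open whether they differ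

The compounds shown hold only methoxy and hydroxy on this oxygen, which leaves open how an ethoxy group, a longer chain on the oxygen or an amine in place of the oxygen would read in this assay. Among the compounds shown here, with only two cores in view, and with both hydroxy compounds given as limits, the true values of compound 3 and compound 4 remain open, as does the outcome of the same change on any further core.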